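From methoxycarbonyl to carboxy in compound 3

This account rests on a few compounds, and the source may have more. Where it says the series, first, only, none or still open, it means among the compounds named here.

Compound 1 (`COc1ccc(-n2cc(C3(O)C=CC(=O)C=C3)nn2)cc1`): 310 nM
Compound 2 (`COC(=O)CCc1ccc(S(=O)(=O)n2c(C3(O)C=CC(=O)C=C3)cc3ccccc32)cc1`): 280 nM

In an ADME assay on MRC5 cells (Homo sapiens) for cytotoxicity, read by fluorescence and resazurin assay, with a stated time of 3 days (on this read-out lower numbers stand for an effect already at smaller amounts and higher numbers for an effect only at larger amounts of compound), compound 2 at 280 nM stands level, within the scatter, with compound 1 at 310 nM and so holds no separate place. Compound 3 (`O=C1C=CC(O)(c2cc3ccccc3n2S(=O)(=O)c2ccc(CCC(=O)O)cc2)C=C1`) departs from compound 2 at one place (hydrogen in place of methyl on an oxygen next to a carbonyl group), with hydrogen in place of methyl on an oxygen next to a carbonyl group, so methoxycarbonyl becomes carboxy. Within the data shown here, no measured pair shows this change, so its size remains open. In this assay a moderate move to a higher number, beyond the scatter, is expected, and the estimated step is a 4.3-fold higher number from compound 2 to compound 3 (0.63 log units; beyond the scatter) for this change. Compound 3 is estimated at 1200 nM within an expected range from 300 nM to 5000 nM until measured.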

Compound 3, half-maximal effective concentration: 3300 nM
The estimate for compound 3 lay 2.8-fold (0.44 log units) below the measured number, and the stated range covers the measured number.
By their numbers in this assay, from the lowest: compounds 2 and 1 (each within the scatter of the next); then compound 3.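

In this assay, the methoxycarbonyl end of the chain proves sensitive to a single small change: with hydrogen in place of methyl, giving carboxy, the number rises by a 12-fold higher number from compound 2 to compound 3 (1.07 log units; beyond the scatter), a large step. Compounds 1 and 2 differ in more than one place, so neither could show this. Nothing measured here accounts for the size of the step.

The compounds shown leave open how an amide or a primary alcohol at this chain end would compare, and whether a longer chain carrying the carboxy group would give a similar number.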